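Replacing the Amide Acyl Group of Compound 1

The source may hold more compounds than are shown below. What is called first, only, known or untested is meant among the compounds shown, and "the series" means these compounds.

Compound 1 `Cc1cc(N2CCC(N3CCCC3C)C2)ccc1NC(=O)C1C(C)(C)C1(C)C`: 37.3 nM
Compound 2 `CC1CCCN1C1CCN(c2ccc(NC(=O)C3C(C)(C)C3(C)C)cc2)C1`: 144 nM

Both measured compounds were tested in an assay on CHO cells for displacement of a labelled ligand from histamine receptor H3 (Macaca mulatta); on this read-out higher numbers stand for weaker inhibition and lower numbers for stronger inhibition. Compound 1 gives 37.3 nM, the lowest number of the two; its nearest neighbour is compound 2, which gives 144 nM. Going by the values given here, the one measured step, a 3.9-fold higher number from compound 1 to compound 2 (0.59 log units; beyond the scatter), comes from hydrogen in place of methyl on an aromatic carbon.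

Compound 3 `Cc1cc(N2CCC(N3CCCC3C)C2)ccc1NC(=O)C1CC2CCC1C2` keeps the core of compound 1 and alters only the group on the carbonyl carbon: a group of 7 heavy atoms (7 carbon; 2 five-membered non-aromatic rings of carbon only) in place of a group of 7 heavy atoms (7 carbon; one three-membered non-aromatic ring of carbon only), on a carbonyl carbon. Among the compounds with values here, no measured pair shares this kind of change; the step from compound 1 to compound 2 touches a different part of the molecule and does not bear on it. The leaving and entering groups are alike in size and neither carries a donor or an acceptor, so there is no basis for expecting a large shift, but also none for ruling one out. The expected step is a 1.6-fold higher number from compound 1 to compound 3 (0.21 log units; within the scatter), treated as uncertain. For compound 3 in this assay the estimate is 60 nM, with a range from 15 nM to 250 nM.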

Compound 3, inhibition constant: 19.9 nM
Estimate against measurement, compound 3: 3.0-fold (0.48 log units) above; low and high end bracket the measured number.
By their numbers in this assay, from the lowest: compounds 3 and 1 (each within the scatter of the next); then compound 2.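

On the carbonyl carbon, the 2,2,3,3-tetramethylcyclopropyl group can be exchanged for a group with 2 five-membered non-aromatic rings of carbon only, and in this assay this gives a 1.9-fold lower number from compound 1 to compound 3 (0.27 log units; within the scatter) so that compound 1 and compound 3 cannot be told apart. Going by these compounds alone, this is the first look at this position, and it shows that a clearly different arrangement of the same 7 carbon atoms can stand there without a step beyond the scatter, although this rests on a single pair of compounds. Nothing measured here explains why the two groups read alike.

From the compounds shown here alone, both groups are made of carbon alone, with no hydrogen-bond donors or acceptors, so it remains open how this assay would respond to an amine, a carboxylic acid or a longer chain such as n-hexyl on the same carbonyl carbon. Also open, going by these compounds, is whether hydrogen in place of methyl on the aromatic carbon, which gave a 3.9-fold higher number from compound 1 to compound 2 (0.59 log units; beyond the scatter) with the 2,2,3,3-tetramethylcyclopropyl group in place, would give a similar step with the group of compound 3.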